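The source may hold more compounds than are shown below. What is called first, only, known or untested is meant among the compounds shown, and "the series" means these compounds.

Measured compounds:
Compound 1, `CCN(CC)S(=O)(=O)c1ccc(S(=O)(=O)N2CCC[C@@H](C(=O)N[C@H]3CC[C@H](OC)CC3)C2)cc1`, gives 1350 nM in a functional assay on MIA PaCa-2 cells (Homo sapiens) for inhibition, read by MTT assay, with a stated time of 7 days; a higher number here means a weaker inhibitor, a lower number a stronger inhibitor.
Compound 2, `O=C([C@@H]1CCCN(S(=O)(=O)c2ccc(S(=O)(=O)C3CCC3)cc2)C1)N1CCC(F)(F)CC1`, gives 9 nM in this assay.
Compound 3, `CCN(CC)C(=O)c1ccc(S(=O)(=O)N2CCC[C@@H](C(=O)N3CCC(F)(F)CC3)C2)cc1`, gives 70 nM in this assay.

Among these three numbers compound 3 holds the second highest place: compound 2 sits below it and compound 1 sits well above it, both gaps lying beyond the scatter. Among the compounds with values here, the single step that can be read between neighbours, a 7.8-fold higher number from compound 2 to compound 3 (0.89 log units; beyond the scatter), shows that swapping a sulfonyl-bearing group for an amide-bearing group on the aromatic ring weakens inhibition by a modest amount.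

Compound 4, `O=C([C@@H]1CCCN(S(=O)(=O)c2ccc(S(=O)(=O)N3CC[C@H](O)C3)cc2)C1)N1CCC(F)(F)CC1`, reverses that kind of swap. The change is (3-hydroxypyrrolidin-1-yl)sulfonyl in place of diethylcarbamoyl on an aromatic carbon. The new group brings back a sulfonyl attached to the aromatic ring, as in compound 2, though now carrying a hydroxypyrrolidine rather than a cyclobutyl. Compound 1, which also has a sulfonyl-linked amine on the ring, cannot be compared directly, since its amide part differs as well.

Within the data shown here, because the only relevant step, a 7.8-fold higher number from compound 2 to compound 3 (0.89 log units; beyond the scatter), went upward when the sulfonyl left, a step downward of roughly that size is expected when a sulfonyl returns. Compound 4 is therefore expected to show a 3.5-fold lower number from compound 3 to compound 4 (0.54 log units; beyond the scatter), landing at an estimated 20 nM with a likely range from 6 nM to 70 nM.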

Compound 4, half-maximal inhibitory concentration: 590 nM
Compound 4: the middle estimate sits 30-fold (1.47 log units) below what was measured; the measured number lies above the stated range.
By their numbers in this assay, from the lowest: compound 2; then compound 3; then compound 4; then compound 1.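

Putting a sulfonyl back on this aromatic carbon, para to a large group, does not by itself bring the number down in this assay: (3-hydroxypyrrolidin-1-yl)sulfonyl in place of diethylcarbamoyl gives an 8.4-fold higher number from compound 3 to compound 4 (0.93 log units; beyond the scatter), the opposite direction to what the earlier step suggested. The group on the sulfonyl sulfur turns out to matter greatly, since 3-hydroxypyrrolidin-1-yl in place of cyclobutyl gives a 66-fold higher number from compound 2 to compound 4 (1.82 log units; beyond the scatter), the largest step among the compounds that differ in one place, so the amide-bearing compound 3 falls between two sulfonyl-bearing compounds rather than simply behind them. Nothing shown here offers a measured reason for either step.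

On these data alone, whether the rise from compound 2 to compound 4 follows the hydroxyl group, the ring nitrogen on the sulfur, or both stays open, and a plain pyrrolidin-1-yl or a cyclopentyl on the same sulfonyl would help to separate these. Also open, as far as these compounds go, are a methoxy group in place of the hydroxyl and the opposite arrangement at the hydroxyl-bearing stereocentre, while compound 1 cannot settle any of this, as it differs from these compounds in more than one place.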